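A few compounds are considered here, and "the series" means these few. Any claim that something is new, unique, unknown or untested is made for them only; others in the source may bear on it.

Measured compounds:
Compound 1, `C/C(=N\O)c1ccc(NC(=O)Cn2nc(-c3ccc(Cl)cc3)nc2N)cc1`, with 18.3%.
Compound 2, `c1ccc(-c2nc3sc(-c4ccccc4)cn3n2)cc1`, with 9%.
Compound 3, `CC(=O)c1ccc(NC(=O)Cn2nc(-c3ccc(Cl)cc3)nc2N)cc1`, with 7.32%.

In a functional assay on SR cells (Homo sapiens) for inhibition, read by sulforhodamine B assay, with a stated time of 48 h, tested at 10 uM (a lower number here means less inhibition of growth, a higher number more inhibition of growth at the concentration tested), compound 2 stands second highest of the three numbers. Its nearest neighbour is compound 3, and its furthest is compound 1; both of these gaps lie within the scatter, so compound 2 cannot be set apart from either of them on these numbers.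

Among the compounds with values here, the only single-place step among the measured compounds is a number 11 percentage points lower from compound 1 to compound 3 (beyond the scatter). That step concerns a different core and a different change, so it says nothing direct about the change considered here.

Compound 4, `COc1ccc(-c2nc3sc(-c4ccccc4)cn3n2)cc1`, differs from compound 2 by methoxy in place of hydrogen on an aromatic carbon. Within the data shown here, no measured step on the shared core of compound 2 and compound 4 bears on a methoxy entering for a hydrogen, and the values of compound 2 and compound 3 show that these low readings sit close together. The expected step is therefore none beyond the scatter, and a number 2 percentage points higher from compound 2 to compound 4 (within the scatter) is the estimated change. For compound 4 the estimate is 11%, with a range from 0% to 25%.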

Compound 4, percent growth inhibition at one concentration: 58%
Compound 4: middle estimate off by 47 percentage points, on the low side; the whole stated range lies below it.
By their numbers in this assay, from the lowest: compounds 3, 2 and 1 (each within the scatter of the next, the first and the last beyond it); then compound 4.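

In this assay, the place on the six-membered aromatic ring of carbon only, para to a large group, turns out to be sensitive to substitution: methoxy in place of hydrogen gives a number 49 percentage points higher from compound 2 to compound 4 (beyond the scatter). Within the data shown here, the only earlier step lay on a different core and involved a different change, so this is the first indication that methoxy at this place on the shared core can shift growth inhibition so strongly. Nothing available explains why this step is so large.

Going by these compounds, it remains open whether the gain is specific to methoxy or would also follow from a hydroxyl, a fluorine or an ethoxy on the same carbon. It is equally unclear whether methoxy would have a similar effect elsewhere on the shared core.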